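Replacing the Trifluoromethoxyphenyl Group of Compound 1

The source may report more compounds than this note shows. Statements on the series, on what has been measured and on what is new or still open speak of the compounds shown alone.

Compound 1 `CC/C(=C(/c1ccc(/C=C/C(=O)O)cc1)c1cc2ccccc2[nH]1)c1ccccc1OC(F)(F)F` and compound 2 `CC/C(=C(/c1ccc(/C=C/C(=O)O)cc1)c1cc2ccccc2[nH]1)c1cccc(C)c1` share one core and differ in a single aromatic group. Within the data shown here, in a functional assay on MCF7 cells (Homo sapiens) for inhibition (a lower number here means a stronger inhibitor, a higher number a weaker inhibitor), compound 1 gives 206 nM, the highest of the two numbers measured so far, and compound 2 gives 140 nM. The step of a 1.5-fold lower number from compound 1 to compound 2 (0.17 log units; within the scatter) is small. Compound 3 `CC/C(=C(/c1ccc(/C=C/C(=O)O)cc1)c1cc2ccccc2[nH]1)c1ccc(Cl)cc1` is the next variation on compound 1: 4-chlorophenyl in place of 2-(trifluoromethoxy)phenyl on a double-bonded chain carbon bound to a double-bonded chain carbon and a saturated chain carbon. Among the measured compounds shown here, no measured step covers this exact exchange; the one step that bears on it, from compound 1 to compound 2, changed a group at the same place and moved the number only within the scatter. On that basis the expected step of a 1.2-fold lower number from compound 1 to compound 3 (0.08 log units; within the scatter) is small, with no clear direction. Compound 3 is therefore estimated at 170 nM in this assay, with a likely range from 70 nM to 420 nM.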

Compound 3, half-maximal inhibitory concentration: 343 nM
Estimate against measurement, compound 3: 2.0-fold (0.30 log units) below, and the stated range covers the measured number.
By their numbers in this assay, from the lowest: compounds 2, 1 and 3 (each within the scatter of the next, the first and the last beyond it).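

At this place on the shared core, the exchange of 2-(trifluoromethoxy)phenyl for 4-chlorophenyl in this assay stays within the scatter, with a 1.7-fold higher number from compound 1 to compound 3 (0.22 log units; within the scatter). Among these compounds, the exchange of 3-methylphenyl for 4-chlorophenyl gives the first step at this place that lies beyond the scatter, though only a modest one, with a 2.5-fold higher number from compound 2 to compound 3 (0.39 log units; beyond the scatter). So this place does respond to the choice of aromatic group, but nothing available explains the gap.

Compound 2 and compound 3 differ in both the substituent and its place on the ring, so the step cannot be assigned to either alone. A 3-chlorophenyl or 4-methylphenyl group would separate these two changes, while an aminophenyl group would test a quite different kind of substituent at this place.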